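Swapping Bromo for Methoxy: Expecting Compound 4

The compounds below may be only part of what the source reports. "The series", "measured", "known", "first", "only" and "open" are said of these compounds alone.

Of the compounds shown here, three built on one shared core have been tested in a functional assay on HeLa cells (Homo sapiens) for cytotoxicity, read by MTT assay; a higher number here means a weaker inhibitor, a lower number a stronger inhibitor. Compound 1 `CCOC(=O)C12C(=O)OCC=C1COC2c1ccccc1F` gives 22100 nM. Compound 2 `CCOC(=O)C12C(=O)OCC=C1COC2c1ccc(F)cc1` gives 22900 nM. Compound 3 `CCOC(=O)C12C(=O)OCC=C1COC2c1ccc(Br)cc1` gives 48700 nM, the highest of the three numbers and so the weakest inhibitor of the set: the step of a 2.1-fold higher number from compound 2 to compound 3 (0.33 log units; beyond the scatter) and the step of a 2.2-fold higher number from compound 1 to compound 3 (0.34 log units; beyond the scatter) both lie beyond the scatter, whereas a 1.0-fold higher number from compound 1 to compound 2 (0.02 log units; within the scatter) does not.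

Compound 4 `CCOC(=O)C12C(=O)OCC=C1COC2c1ccc(OC)cc1` has not yet been measured. It differs from compound 3 in a single place: methoxy in place of bromo on an aromatic carbon. Within the data shown here, no measured step replaces a halogen with a methoxy group, so the only direct guide is that exchanging fluoro for bromo at this same place, a 2.1-fold higher number from compound 2 to compound 3 (0.33 log units; beyond the scatter), raised the number modestly; putting a different group there could undo part of that rise, or leave the number where it is. The expected step of a 1.6-fold lower number from compound 3 to compound 4 (0.21 log units; within the scatter) is therefore small, most likely toward a somewhat lower number, and may well stay within the scatter. Compound 4 is expected to give about 30000 nM in this assay, with a plausible range from 12000 nM to 80000 nM.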

Compound 4, half-maximal inhibitory concentration: 18300 nM
The estimate for compound 4 lay 1.6-fold (0.21 log units) above the measured number; the measured number falls inside the stated range.
By their numbers in this assay, from the lowest: compounds 4, 1 and 2 (each within the scatter of the next); then compound 3.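

In this assay, replacing bromo with methoxy on the aromatic carbon para to a large group gives a 2.7-fold lower number from compound 3 to compound 4 (0.43 log units; beyond the scatter), so the number at this place also comes down with a group that is not a halogen. Against fluoro at the same place, methoxy gives a 1.3-fold lower number from compound 2 to compound 4 (0.10 log units; within the scatter), so these two quite different groups cannot be told apart here; bromo is the one that stands apart among the three groups at this place, and compound 3 remains the weakest inhibitor of the set. What makes bromo differ from the other two groups is not explained by anything available here.

On these data alone, it remains open whether the higher number belongs to bromo alone or would also come with chloro or iodo at this place, and what an amine, a carboxylic acid or a longer chain such as butoxy would do there. All the changes shown lie on the aromatic ring, so the effect of altering the ethyl ester on the shared core also stays unknown.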